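Difluorophenyl ketone in the trimethoxyphenyl pyrazole enone series

This account rests on a few compounds, and the source may have more. Where it says the series, first, only, none or still open, it means among the compounds named here.

Measured so far in a functional assay on OVCAR-8 cells (Homo sapiens) for inhibition, read by sulforhodamine B assay, with a stated time of 48 h; a lower number here means that less compound is tolerated, a higher number that more compound is tolerated:
- compound 1 `COc1cc(-c2cc(/C=C/C(=O)c3ccc(N)cc3)[nH]n2)cc(OC)c1OC` gives 34900 nM
- compound 2 `COc1cc(-c2cc(/C=C/C(=O)c3ccc(Cl)c(Cl)c3)[nH]n2)cc(OC)c1OC` sits at the limit > 100000 nM
- compound 3 `COc1ccc(C(=O)/C=C/c2cc(-c3cc(OC)c(OC)c(OC)c3)n[nH]2)cc1` sits at the limit > 100000 nM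

Compound 3 stands at a limit of this assay, not at a number; the same holds for compound 2, as the limit of > 100000 nM in this assay, at which 2 of the 3 values shown sit, records. Only compound 1 gives a number. Compound 4 `COc1cc(-c2cc(/C=C/C(=O)c3ccc(F)c(F)c3)[nH]n2)cc(OC)c1OC` differs from compound 3 by 3,4-difluorophenyl in place of 4-methoxyphenyl on a carbonyl carbon.

The measured steps that bear on this are an at least 2.8-fold higher number from compound 1 to compound 2 (0.45 log units; beyond the scatter), which leads to the limit, and a step that the two limits leave unreadable from compound 2 to compound 3. The exchange of an aryl group on the carbonyl carbon for a 3,4-dihalophenyl has so far ended at the limit in compound 2, and compound 3 already stands there. A 3,4-difluorophenyl in the same place is therefore expected to give no readable step in this assay: for compound 4 the estimate is 100000 nM (range 40000 nM to 250000 nM), most likely again reported as a limit, so that the expected step of a number no higher from compound 3 to compound 4 (the limit leaves the size open) cannot be read as a change beyond the scatter.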

Compound 4, concentration lethal to 50% of the cells: > 100000 nM
Compound 4 was reported as a limit; the forecaster's own chance of this, stated with the estimate: 80%; the middle value lies on the limit itself.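

In this assay compound 4 gives > 100000 nM, which is a limit of the assay and not a number. Putting 3,4-difluorophenyl in place of 4-aminophenyl on the carbonyl carbon gives an at least 2.8-fold higher number from compound 1 to compound 4 (0.45 log units; beyond the scatter), so among the aryl groups shown on this carbon, only 4-aminophenyl in compound 1 yields a number. The steps among compound 2, compound 3 and compound 4 cannot be read, and three different aryl groups now share one mark: the limit of > 100000 nM in this assay, at which 3 of the 4 values shown sit.

From the compounds shown here alone, how compound 2, compound 3 and compound 4 rank against one another stays open. Also open, going by these compounds, is whether the number of compound 1 belongs to the amine alone, a question that a 4-hydroxyphenyl or 4-(dimethylamino)phenyl on the carbonyl carbon would address.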